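The source may hold more compounds than are shown below. What is called first, only, known or untested is meant among the compounds shown, and "the series" means these compounds.

This account follows one change on a shared core, made at the aryl group that sits on an amide-type nitrogen. Compound 1 `Cn1c(Cc2nn(C)c(=O)c3ccccc23)nnc1SCCCC(=O)Nc1ccc(Cl)cc1Cl` is measured in an assay on isolated protein (Mus musculus) for inhibition of IL15-IL15 receptor (Homo sapiens), read by resazurin assay, with stated times of 30 min and 2.5 days (on this read-out lower numbers stand for stronger inhibition and higher numbers for weaker inhibition), and gives 9800 nM. Compound 3 `Cn1c(Cc2nn(C)c(=O)c3ccccc23)nnc1SCCCCCCCCCCC(=O)Nc1ccc(Cl)cc1`, which carries a much longer chain between the core and the amide, gives in this assay a value of 20000 nM. Compound 2 `CCCOc1ccc(NC(=O)CSc2nnc(Cc3nn(C)c(=O)c4ccccc34)n2C)cc1` reaches no number in this assay but only a limit, > 30000 nM, and so it stands at the limit of > 30000 nM in this assay, at which 1 of the 3 values shown sits; its true value is not known beyond that.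

The step considered here leads to compound 4 `Cn1c(Cc2nn(C)c(=O)c3ccccc23)nnc1SCC(=O)Nc1ccc(F)cc1F`, which differs from compound 2 in one place: 2,4-difluorophenyl in place of 4-propoxyphenyl on an amide-type nitrogen. Within the data shown here, no measured pair among the three compounds shows this exact change. What the numbers do show is that compound 1, whose aryl group on the amide-type nitrogen bears chlorine rather than an alkoxy chain, gives 9800 nM. Compound 2, for its part, reaches only its limit in this assay. On that basis the expected step is an at least 2.0-fold lower number from compound 2 to compound 4 (0.30 log units; that floor lies within the scatter), a move toward a measurable value rather than a step beyond the scatter in the other direction. Compound 4 is estimated in this assay at 15000 nM, with a range from 5000 nM to 40000 nM.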

Compound 4, half-maximal inhibitory concentration: "not active" (no number reported)
For compound 4 the study gives words and no number; no gap can be computed for the estimate.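

Compound 4 is reported only in words, as not active, with no number, and compound 2 has only a limit, so no step can be read from compound 2 to compound 4. The compounds shown leave open whether 2,4-difluorophenyl in place of 4-propoxyphenyl on an amide-type nitrogen changes the inhibition at all, and by how much.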